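Triazole-linked aryl ureas: varying the aryl on the triazole

A few compounds are considered here, and "the series" means these few. Any claim that something is new, unique, unknown or untested is made for them only; others in the source may bear on it.

The series shares a diaryl urea core linked through an ether to a triazole that carries an aryl group. Compound 1 `CC(C)c1ccc(-n2cc(COc3cccc(NC(=O)Nc4ccc(Cl)c(C(F)(F)F)c4)c3)nn2)cc1` gives 2470 nM in a functional assay on HepG2 cells (Homo sapiens) for inhibition, read by MTT assay, with a stated time of 72 h; a higher number here means a weaker inhibitor, a lower number a stronger inhibitor. Compound 2 `O=C(Nc1cccc(OCc2cn(-c3ccc(Cl)cc3)nn2)c1)Nc1ccc(Cl)c(C(F)(F)F)c1` gives 2490 nM in this assay. Within the data shown here, the one measured step, a 1.0-fold higher number from compound 1 to compound 2 (0.00 log units; within the scatter), leaves the two numbers within the scatter of each other, so compound 2 and compound 1 cannot be told apart on these data, and no order between them is claimed.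

Compound 3 `O=C(Nc1cccc(OCc2cn(-c3ccccc3C(F)(F)F)nn2)c1)Nc1ccc(Cl)c(C(F)(F)F)c1` is not yet measured. It differs from compound 2 by 2-(trifluoromethyl)phenyl in place of 4-chlorophenyl on an aromatic nitrogen, that is, on an aromatic nitrogen of a five-membered aromatic ring with 3 nitrogen. This is the same place that was varied in the step from compound 1 to compound 2, where the change from isopropyl to chloro on that aryl left the number unchanged within the scatter. Among the measured compounds shown here, with only that flat step to go on, the expected step of a 1.0-fold higher number from compound 2 to compound 3 (0.00 log units; within the scatter) is none beyond the scatter, in either direction. Compound 3 is therefore estimated at 2500 nM, with a range from 1000 nM to 6500 nM.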

Compound 3, half-maximal inhibitory concentration: 2320 nM
Beside the measured number, compound 3's estimate is 1.1-fold (0.03 log units) above it; the range from low to high includes it.
By their numbers in this assay, from the lowest: compounds 3, 1 and 2 (each within the scatter of the next).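

In this assay, 2-(trifluoromethyl)phenyl in place of 4-chlorophenyl on the aromatic nitrogen gives a 1.1-fold lower number from compound 2 to compound 3 (0.03 log units; within the scatter), and the same group in place of 4-isopropylphenyl gives a 1.1-fold lower number from compound 1 to compound 3 (0.03 log units; within the scatter). The earlier pair showed only an exchange between two 4-substituted phenyl groups, whereas compound 3 also moves to a 2-substituted phenyl and to a larger group, with 10 heavy atoms against 7 for 4-chlorophenyl, and still stays within the scatter of both compound 1 and compound 2. Across these three aryl groups the position therefore shows no measurable response, and nothing to hand bears on this flat result.

As far as these compounds go, whether any group at this position can move the number beyond the scatter remains open, for example a phenyl carrying an amine or a carboxylic acid, or a longer alkyl chain in place of the aryl. The compounds shown also keep the rest of the shared core fixed, so the weight of the 4-chloro-3-(trifluoromethyl)phenyl group on the urea and of the ether link is not addressed.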